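The compounds below may be only part of what the source reports. "The series", "measured", "known", "first", "only" and "open" are said of these compounds alone.

Working notes on a small urea series examined in an ADME assay on the whole organism with Oryza sativa as the target, tested at 10 uM; a lower number here means a stronger effect, a higher number a weaker effect of the compound at the concentration tested. Of the compounds shown here, two have numbers so far. Compound 1 `C[C@@H](NC(=O)Nc1ccccc1Cl)c1ccccc1` carries a chloro on one ring of the shared core, and in this assay compound 1 gives 93%. Compound 2 `C[C@@H](NC(=O)Nc1cccc(Cl)c1)c1ccccc1` carries the chloro at another position of that ring, and in this assay compound 2 gives 83%. Among the compounds with values here, of the two numbers, that of compound 2 is the smaller, but the gap to compound 1 lies within the usual scatter, so the two values cannot be told apart; no single-point step is defined between them.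

The next compound is compound 3 `C[C@@H](NC(=O)Nc1cc(Cl)ccc1Cl)c1ccccc1`, differing from compound 2 by chloro in place of hydrogen on an aromatic carbon.

The two numbers in hand give no guide to the size of such a change, since neither pair differs in only one place. The step from compound 2 to compound 3 in this assay is therefore expected to be small, a number 3 percentage points lower from compound 2 to compound 3 (within the scatter), and not clearly beyond the scatter. On that basis compound 3 is estimated at 80% in this assay, with a range from 60% to 98%.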

Compound 3, a percentage reported as activity, at one concentration (the size of the read-out at that concentration, not a potency): 101%
Compound 3: the middle estimate sits 21 percentage points below what was measured; the whole stated range lies below it.
By their numbers in this assay, from the lowest: compounds 2, 1 and 3 (each within the scatter of the next, the first and the last beyond it).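

In this assay, within the data shown here, chloro in place of hydrogen on an aromatic carbon, ortho to a large group and para to a chloro group, gives a number 18 percentage points higher from compound 2 to compound 3 (beyond the scatter), the first step that stands clear of the scatter. The same kind of replacement starting from the other monochloro compound gives a number 8 percentage points higher from compound 1 to compound 3 (within the scatter), so adding a second chloro does not read alike on the two compounds. The change therefore has a visible effect on the number when made on compound 2 but none that can be told from the scatter when made on compound 1, and a single chloro-for-hydrogen step cannot be assumed to carry over within this small set.

No measurement at hand bears on why the two steps read differently. On these data alone, whether a methyl, a methoxy or an amine at this same position on compound 2 would give a step of similar size remains open, as does whether a chloro on the other aromatic ring of the shared core would have any effect on the number.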